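The source may hold more compounds than are shown below. What is called first, only, known or untested is meant among the compounds shown, and "the series" means these compounds.

Compound 3 `COc1cc(N2C(N)=C(C#N)C(c3ccc(C)cc3)C3=C2CC(C)(C)CC3=O)cc(OC)c1OC` was examined in a functional assay on Ehrlich cells (Mus musculus) for cytotoxicity, tested at 100 ug/mL (a higher number here means a stronger effect of the compound at the concentration tested, a lower number a weaker effect), where compound 3 gives 90%. That places it level with compound 2 `COc1cc(N2C(N)=C(C#N)C(c3c(O)ccc4ccccc34)C3=C2CC(C)(C)CC3=O)cc(OC)c1OC`, which in this assay gives 90%; the two stand together at the top of the three numbers, and the step of no change at the digits printed from compound 2 to compound 3 (within the scatter) shows no change. Compound 1 `COc1cc(N2C(N)=C(C#N)C(c3ccc(OC)c4ccccc34)C3=C2CC(C)(C)CC3=O)cc(OC)c1OC` in this assay gives 40%, and the steps of a number 50 percentage points higher from compound 1 to compound 2 (beyond the scatter) and a number 50 percentage points higher from compound 1 to compound 3 (beyond the scatter) are both large.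

Compound 4 `COc1cc(N2C(N)=C(C#N)C(c3ccc(C)o3)C3=C2CC(C)(C)CC3=O)cc(OC)c1OC` has not yet been measured. It differs from compound 3 in one place: 5-methylfuran-2-yl in place of 4-methylphenyl on a saturated ring carbon. All three measured steps swap the group on this same saturated ring carbon, so all of them bear on the question. Two of them were large and one was within the scatter, so the outcome of a swap at this position can be anything from nothing to a large shift. Among the compounds with values here, no measured step involves a five-membered aromatic ring with one hetero atom, so the direction for compound 4 is not fixed by the data. Compound 4 is therefore expected to land a little below compound 3, at 75% with a range from 45% to 95%. The expected step of a number 15 percentage points lower from compound 3 to compound 4 (beyond the scatter) is an estimate only.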

Compound 4, a percentage reported as activity, at one concentration (the size of the read-out at that concentration, not a potency): 50%
For compound 4 the middle estimate is 25 percentage points above the measured one; measured number inside the range.
By their numbers in this assay, from the lowest: compounds 1 and 4 (each within the scatter of the next); then compounds 2 and 3 (each within the scatter of the next).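

In this assay, within the data shown here, a large fall at this saturated ring carbon had so far come only with the 4-methoxynaphthalen-1-yl group, but compound 4 shows that a single-ring group can bring one too: replacing 4-methylphenyl gives a number 40 percentage points lower from compound 3 to compound 4 (beyond the scatter) and replacing 2-hydroxynaphthalen-1-yl gives a number 40 percentage points lower from compound 2 to compound 4 (beyond the scatter). Against the 4-methoxynaphthalen-1-yl group the result is a number 10 percentage points higher from compound 1 to compound 4 (within the scatter), so the four compounds form two levels, and each level holds one naphthalene group and one single-ring group, which means that the number of rings in the group does not sort them. The compounds shown offer no independent measurement that could explain this fall.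

From the compounds shown here alone, it remains open whether the fall follows the oxygen in the ring, the five-membered ring or the two together, and a thiophene ring carrying the same methyl group, or a pyridine ring, would help to separate these. Also open, going by these compounds, is how an amine or a carboxylic acid on the aromatic ring would read out, and all of these numbers describe the effect at one concentration, not potency.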